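Side-chain variation on the amide of the shared core

The source may hold more compounds than are shown below. What is called first, only, known or untested is meant among the compounds shown, and "the series" means these compounds.

Three analogues of the shared core differ only in the side chain on the amide-type nitrogen. In a functional assay on MCF7 cells (Homo sapiens) for cytotoxicity, read by MTT assay, with a stated time of 24 h (on this read-out higher numbers stand for weaker inhibition and lower numbers for stronger inhibition), compound 1 `COC(=O)[C@H](NC(=O)Cn1cc(C2=C(c3c[nH]c4ccccc34)C(=O)N(C)C2=O)c2ccccc21)[C@@H](C)O` gives 22900 nM, compound 2 `COC(=O)[C@@H](C)NC(=O)Cn1cc(C2=C(c3c[nH]c4ccccc34)C(=O)N(C)C2=O)c2ccccc21` gives 15300 nM, and compound 3 `COC(=O)[C@@H](CO)NC(=O)Cn1cc(C2=C(c3c[nH]c4ccccc34)C(=O)N(C)C2=O)c2ccccc21` gives 24500 nM. Compound 3 carries the highest number of the three, but its separation from the others is small: a 1.1-fold higher number from compound 1 to compound 3 (0.03 log units; within the scatter) and a 1.6-fold higher number from compound 2 to compound 3 (0.20 log units; within the scatter). Likewise a 1.5-fold lower number from compound 1 to compound 2 (0.18 log units; within the scatter).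

Compound 4 `COC(=O)[C@@H](CC(C)C)NC(=O)Cn1cc(C2=C(c3c[nH]c4ccccc34)C(=O)N(C)C2=O)c2ccccc21` is not yet measured in this assay. Relative to compound 3 it brings (isopropyl in place of hydroxy on a saturated chain carbon, two bonds along the chain from an amide-type nitrogen and a carbonyl carbon). The nearest measured step is the one introducing the hydroxy at that position, a 1.6-fold higher number from compound 2 to compound 3 (0.20 log units; within the scatter), which did not move the number beyond the scatter; the change at the same carbon between compound 1 and compound 2 was also within the scatter. On this basis the step from compound 3 to compound 4 is expected to be a 1.4-fold lower number from compound 3 to compound 4 (0.13 log units; within the scatter), with no movement beyond the scatter anticipated. Compound 4 is therefore estimated at 18000 nM in this assay, within the range 8000 nM to 40000 nM.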

Compound 4, half-maximal inhibitory concentration: 37400 nM
Compound 4: the middle estimate sits 2.1-fold (0.32 log units) below what was measured; low and high end bracket the measured number.
By their numbers in this assay, from the lowest: compounds 2, 1, 3 and 4 (each within the scatter of the next, the first and the last beyond it).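

At the saturated chain carbon, two bonds along the chain from an amide-type nitrogen and a carbonyl carbon, the isobutyl side chain gives the first separation beyond the scatter in this set of analogues in this assay: a 2.4-fold higher number from compound 2 to compound 4 (0.39 log units; beyond the scatter), a modest step. The same side chain stays within the scatter against both hydroxy-bearing side chains, with a 1.5-fold higher number from compound 3 to compound 4 (0.18 log units; within the scatter) and a 1.6-fold higher number from compound 1 to compound 4 (0.21 log units; within the scatter), so the data separate isobutyl from methyl but from neither hydroxymethyl nor 1-hydroxyethyl. No measurement shown here gives a reason for the separation.

Going by these compounds, whether a longer chain at this carbon would move the number further from that of compound 2 remains open. On these data alone, the effect of an amine or a carboxylic acid on this side chain also remains open.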